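The source may report more compounds than this note shows. Statements on the series, on what has been measured and on what is new or still open speak of the compounds shown alone.

Compound 1 `Cc1ccc(-c2cs/c(=N/NC(=O)CSc3nnnn3-c3ccccc3)n2-c2ccccc2)cc1` gives 29.5% in a functional assay on C6 cells (Rattus norvegicus) for cytotoxicity, read by MTT assay, with a stated time of 24 h, tested at 50 ug/mL; a higher number here means a weaker effect of the compound at the concentration tested, a lower number a stronger effect.
Compound 2 `Cc1ccc(-c2cs/c(=N/NC(=O)CSc3nncn3C)n2-c2ccccc2)cc1` gives 53.8%.
Compound 3 `Cc1ccc(-c2cs/c(=N/NC(=O)CSc3ncccn3)n2-c2ccccc2)cc1` gives 64.4%.

Compound 1 stands lowest of the three in this assay, the strongest effect at this concentration: the steps of a number 24.3 percentage points higher from compound 1 to compound 2 (beyond the scatter) and a number 34.9 percentage points higher from compound 1 to compound 3 (beyond the scatter) both lie beyond the scatter, as does a number 10.6 percentage points higher from compound 2 to compound 3 (beyond the scatter). Compound 4 `N#Cc1ccc(-c2cs/c(=N/NC(=O)CSc3nnnn3-c3ccccc3)n2-c2ccccc2)cc1` differs from compound 1 by cyano in place of methyl on an aromatic carbon. For the measured compounds named here, none of the measured steps touches this part of the molecule; all three vary only the group on the sulfur, so no measured step bears directly on the change. With nothing to suggest a shift, a step of a number 2.5 percentage points higher from compound 1 to compound 4 (within the scatter) is expected, within the scatter. Compound 4 is therefore estimated at 32%, in the range 15% to 55%.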

Compound 4, a percentage reported as activity, at one concentration (the size of the read-out at that concentration, not a potency): 61.1%
Beside the measured number, compound 4's estimate is 29.1 percentage points below it; the whole stated range lies below it.
By their numbers in this assay, from the lowest: compound 1; then compounds 2, 4 and 3 (each within the scatter of the next, the first and the last beyond it).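

In this assay, the aromatic ring carrying the methyl group proves to be a sensitive position: cyano in place of methyl gives a number 31.6 percentage points higher from compound 1 to compound 4 (beyond the scatter). This change, away from the sulfur, is graded large, as is the change on the sulfur that gives a number 34.9 percentage points higher from compound 1 to compound 3 (beyond the scatter). Nothing shown here accounts for the step. The compounds shown hold only methyl and cyano at this position, so it stays open how an amine, a chlorine atom or a carboxylic acid there would read. From the compounds shown here alone, it also stays open whether the cyano step carries over to compounds with pyrimidin-2-yl or 4-methyl-4H-1,2,4-triazol-3-yl on the sulfur.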